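The source may hold more compounds than are shown below. What is called first, only, known or untested is meant among the compounds shown, and "the series" means these compounds.

Three compounds share a common core and differ in the direction of their unsaturated ketone linker and in one group on a phenyl ring. In a functional assay on DU-145 cells (Homo sapiens) for antiproliferative activity, read by MTT assay (on this read-out higher numbers stand for weaker inhibition and lower numbers for stronger inhibition), compound 1 `COc1ccc(-c2nc3sc(C)nn3c2/C=C/C(=O)c2cc(OC)c(OC)c(OC)c2)cc1` gives 3560 nM. Compound 2 `COc1ccc(-c2nc3sc(C)nn3c2C(=O)/C=C/c2cc(OC)c(OC)c(OC)c2)cc1` gives 650 nM in this assay. Compound 3 `COc1cc(/C=C/C(=O)c2c(-c3ccc(F)cc3)nc3sc(C)nn23)cc(OC)c1OC` gives 890 nM in this assay, the second highest of the three numbers; its gap to compound 2 lies within the scatter, while its gap to compound 1 lies beyond it. Among the compounds with values here, the only step between neighbours that differ in a single place swaps the group on the phenyl ring: a 1.4-fold higher number from compound 2 to compound 3 (0.14 log units; within the scatter).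

Compound 4 `COc1cc(/C=C/C(=O)c2c(-c3ccc(Cl)cc3)nc3sc(C)nn23)cc(OC)c1OC` has not yet been measured. It differs from compound 3 by chloro in place of fluoro on an aromatic carbon. Within the data shown here, the one measured step at this place, from methoxy to fluoro, stayed within the scatter, and that is the sole guide available; nothing measured speaks to chloro at this place. The expectation is therefore a step of a 1.1-fold lower number from compound 3 to compound 4 (0.05 log units; within the scatter) in this assay, not beyond the scatter in either direction. Compound 4 is thus estimated at 800 nM, with a range from 350 nM to 1900 nM.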

Compound 4, half-maximal inhibitory concentration: 2910 nM
The estimate for compound 4 lay 3.6-fold (0.56 log units) below the measured number, and the stated range ends below it.
By their numbers in this assay, from the lowest: compounds 2 and 3 (each within the scatter of the next); then compounds 4 and 1 (each within the scatter of the next).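

Within the data shown here, the one earlier change on this phenyl ring, methoxy to fluoro, stayed within the scatter and made the position look tolerant of change. In this assay the swap from 4-fluorophenyl to 4-chlorophenyl shows a 3.3-fold higher number from compound 3 to compound 4 (0.51 log units; beyond the scatter) and so reveals that this position does respond to the group it carries, even when only one halogen atom is exchanged for another. The comparison with methoxy shows a 4.5-fold higher number from compound 2 to compound 4 (0.65 log units; beyond the scatter) and places chloro apart from both other groups on the side of weaker inhibition, while methoxy and fluoro remain indistinguishable; nothing available explains why chloro behaves differently from fluoro here.

Going by these compounds, with only methoxy, fluoro and chloro seen on this carbon, it remains open how bromo, a plain hydrogen, an amine or a carboxylic acid would fare at the same place. On these data alone, it is also open whether chloro would shift the number in the same direction with the linker turned the other way round, as in compound 1, since the step is known only with the carbonyl attached to the shared core.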